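A few compounds are considered here, and "the series" means these few. Any claim that something is new, unique, unknown or untested is made for them only; others in the source may bear on it.

Measured in an ADME assay on NHDF cells (Homo sapiens) for cytotoxicity, read by MTT assay, with a stated time of 72 h; on this read-out lower numbers stand for stronger inhibition and higher numbers for weaker inhibition:
- compound 1 `COc1cccc(/C=C2\CCC/C(=C\c3ccc(Cl)cc3)C2=O)c1OC`: 18600 nM
- compound 2 `COc1ccc(/C=C2\CCC/C(=C\c3cccc(OC)c3OC)C2=O)cc1OC`: 14900 nM
- compound 3 `COc1cc(/C=C2\CCC/C(=C\c3cccc(OC)c3OC)C2=O)ccc1O`: 14300 nM

Compound 2 lies within the scatter of both other compounds, so the three values form one group with no order among them. Compound 4 `COc1ccccc1/C=C1\CCC/C(=C\c2ccc(OC)c(OC)c2)C1=O` has not yet been measured. Its difference from compound 2 is hydrogen in place of methoxy on an aromatic carbon, in words hydrogen in place of methoxy on an aromatic carbon, ortho to a methoxy group.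

Within the data shown here, two measured steps bear on this. The closer one is a 1.0-fold lower number from compound 2 to compound 3 (0.02 log units; within the scatter), which puts hydrogen in place of methyl on an oxygen on an aromatic ring. The other is a 1.3-fold lower number from compound 1 to compound 3 (0.11 log units; within the scatter), which puts 4-hydroxy-3-methoxyphenyl in place of 4-chlorophenyl. Both lie within the scatter, but neither is the same change as this one, so the evidence is indirect. No step beyond the scatter is therefore expected in this assay.

The estimate amounts to an expected 1.0-fold higher number from compound 2 to compound 4 (0.00 log units; within the scatter). Compound 4 is expected at 15000 nM, with an estimated range of 8000 nM to 28000 nM.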

Compound 4, half-maximal inhibitory concentration: 18100 nM
Beside the measured number, compound 4's estimate is 1.2-fold (0.08 log units) below it; the measured number falls inside the stated range.
By their numbers in this assay, from the lowest: compounds 3, 2, 4 and 1 (each within the scatter of the next).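

In this assay the step of a 1.2-fold higher number from compound 2 to compound 4 (0.08 log units; within the scatter) lies within the scatter, and it is the first shown that takes a whole methoxy group off an aromatic carbon, ortho to a methoxy group, and leaves hydrogen there. The earlier steps shown here had only put hydrogen in place of methyl on an oxygen or exchanged one whole substituted phenyl group for another, so this result adds that the read-out also stays within the scatter when both the carbon and the oxygen of this methoxy group leave. Nothing measured here offers a reason for this outcome.

What the compounds shown leave open is whether another group at this place, such as an amine or a carboxylic acid, would give a step beyond the scatter. They also leave open whether the same exchange of methoxy for hydrogen would stay within the scatter at other places on the aromatic rings.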